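Nitro to methyl on the aryl ring of compound 1

This account rests on a few compounds, and the source may have more. Where it says the series, first, only, none or still open, it means among the compounds named here.

Compound 1 `O=[N+]([O-])c1ccccc1/C=N\NC(=S)N(Cc1ccccc1)Cc1ccccc1` is the reference point of this set. In an ADME assay on Vero cells (Chlorocebus sabaeus) for cytotoxicity, read by MTT assay, with a stated time of 72 h (on this read-out higher numbers stand for lower toxicity in this test and lower numbers for higher toxicity in this test), compound 1 reaches only a limit, < 155000 nM; this is the limit at which (the limit of < 155000 nM in this assay, at which 1 of the 3 values shown sits). Compound 2 `C=CCN(CC=C)C(=S)N/N=C(/C)c1ccccc1` gives 229000 nM in this assay. Compound 3 `C=CCN(CC=C)C(=S)N/N=C\c1ccccc1O` has "not determined" (no result reported) in this assay, so no number stands for it. Compound 4 `Cc1ccccc1/C=N\NC(=S)N(Cc1ccccc1)Cc1ccccc1` is the unmeasured analogue; it differs from compound 1 by methyl in place of nitro on an aromatic carbon. Going by the values given here, no measured pair isolates this change, so the expected step from compound 1 to compound 4 is a step that the limit leaves unreadable from compound 1 to compound 4, not clearly beyond the scatter in either direction. Compound 4 is therefore estimated at 150000 nM in this assay, within 40000 nM to 400000 nM.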

Compound 4, half-maximal cytotoxic concentration: 167000 nM
The estimate for compound 4 lay 1.1-fold (0.05 log units) below the measured number; low and high end bracket the measured number.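

In this assay compound 4 gives 167000 nM, a single number for this shared core with 2-methylphenyl in place of 2-nitrophenyl. Compound 1 holds only a limit, < 155000 nM. Methyl in place of nitro gives an at least 1.0-fold higher number from compound 1 to compound 4 (0.03 log units; that floor lies within the scatter), and the true size of this step stays unreadable because one end of it is a limit: the limit of < 155000 nM in this assay, at which 1 of the 4 values shown sits.

Open, as far as these compounds go, is how an amine, a carboxylic acid or a methoxy group on this aromatic carbon would read in this assay. Also open, from the compounds shown here alone, is whether a single number for compound 1 would separate it from compound 4.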